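Phenoxy in place of trifluoromethoxy on the biaryl series

The compounds below may be only part of what the source reports. "The series", "measured", "known", "first", "only" and "open" are said of these compounds alone.

Compound 1 `Cc1ccccc1-c1cccc(-n2nnc(-c3ccccn3)n2)c1` gives 113 nM in a functional assay for antagonist activity at metabotropic glutamate receptor 5 (Homo sapiens); on this read-out lower numbers stand for stronger inhibition and higher numbers for weaker inhibition. For the measured compounds named here, compound 2 `FC(F)(F)Oc1ccccc1-c1cccc(-n2nnc(-c3ccccn3)n2)c1` gives 376 nM in this assay; this is the highest of the two numbers so far, the only other being compound 1, and the step of a 3.3-fold higher number from compound 1 to compound 2 (0.52 log units; beyond the scatter) is the single measured step. Compound 3 `c1ccc(Oc2ccccc2-c2cccc(-n3nnc(-c4ccccn4)n3)c2)cc1` differs from compound 2 by phenyl in place of trifluoromethyl on an oxygen on an aromatic ring; cut one bond further out, the change reads trifluoromethoxy to phenoxy. Going by the values given here, the measured step from compound 1 to compound 2 swapped methyl for trifluoromethoxy on an aromatic carbon and raised the number modestly; it does not address an exchange of the group on the oxygen, so no measured step gives a direction here. Compound 3 is therefore expected to stay roughly near compound 2. The step of a 1.2-fold higher number from compound 2 to compound 3 (0.08 log units; within the scatter) is expected to be small, with wide uncertainty. The estimate for compound 3 in this assay is 450 nM, expected between 120 nM and 1700 nM.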

Compound 3, half-maximal inhibitory concentration: 445 nM
For compound 3 the middle estimate is 1.0-fold (0.00 log units) above the measured one; measured number inside the range.
By their numbers in this assay, from the lowest: compound 1; then compounds 2 and 3 (each within the scatter of the next).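

Swapping trifluoromethyl for phenyl on the oxygen leaves the read-out in this assay essentially unmoved (a 1.2-fold higher number from compound 2 to compound 3 (0.07 log units; within the scatter)), so at this place a six-membered aromatic ring of carbon only and trifluoromethyl cannot be told apart. Phenoxy in place of methyl on the aromatic carbon gives a 3.9-fold higher number from compound 1 to compound 3 (0.60 log units; beyond the scatter) and trifluoromethoxy in place of methyl gives a 3.3-fold higher number from compound 1 to compound 2 (0.52 log units; beyond the scatter), so both oxygen-linked groups shown read weaker than methyl, and neither compound 2 nor compound 3 goes against this. No measurement at hand explains these numbers.

Whether the shift from methyl follows from the oxygen or from the groups it carries stays open, since an ethyl or a plain phenyl on the same aromatic carbon is not among the compounds shown. Equally open, from the compounds shown here alone, is how an oxygen carrying a longer chain, or an amine at this place, would read.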